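Trading a Ring Amine for an Open Chain

A few compounds are considered here, and "the series" means these few. Any claim that something is new, unique, unknown or untested is made for them only; others in the source may bear on it.

In a functional assay on HCT-116 cells (Homo sapiens) for cytotoxicity, read by MTT assay, with a stated time of 72 h (a lower number here means a stronger inhibitor, a higher number a weaker inhibitor), compound 1 `O=C1c2c[n+]([O-])c3ccccc3c2C(=O)c2c1c1ccccc1n2Cc1cn(C[C@H](O)CO)nn1` gives 400 nM. Compound 2 `O=C1c2c[n+]([O-])c3ccccc3c2C(=O)c2c1c1ccccc1n2CCN1CCCCC1` gives 780 nM, so these two values lie within the scatter of each other and cannot be ranked. Compound 3 `CN(C)CCCCn1c2c(c3ccccc31)C(=O)c1c[n+]([O-])c3ccccc3c1C2=O` keeps the shared core and alters the side chain: 2-(dimethylamino)ethyl in place of piperidin-1-yl on a saturated chain carbon, two bonds along the chain from an aromatic nitrogen. Put simply, 2-(dimethylamino)ethyl stands in place of piperidin-1-yl on a saturated chain carbon, two bonds along the chain from an aromatic nitrogen. Within the data shown here, only one measured step bears on this: a 2.0-fold higher number from compound 1 to compound 2 (0.29 log units; within the scatter). That step exchanged two very different groups on the chain, yet stayed within the scatter. One step is thin evidence, but it gives no reason to expect a real shift in either direction in this assay. The expected step is a 1.2-fold lower number from compound 2 to compound 3 (0.08 log units; within the scatter), which is no change beyond the scatter. For compound 3, the estimated value is 650 nM, with an expected range of 220 nM to 1900 nM.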

Compound 3, half-maximal inhibitory concentration: 450 nM
The estimate for compound 3 lay 1.4-fold (0.16 log units) above the measured number, and the stated range covers the measured number.
By their numbers in this assay, from the lowest: compounds 1, 3 and 2 (each within the scatter of the next).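

Opening the piperidin-1-yl ring into 2-(dimethylamino)ethyl, on a saturated chain carbon, two bonds along the chain from an aromatic nitrogen, gives a 1.7-fold lower number from compound 2 to compound 3 (0.24 log units; within the scatter) in this assay, so among these compounds the ring is not needed for a value in this range. Compared with the triazole-bearing side chain, the open amine chain gives a 1.1-fold higher number from compound 1 to compound 3 (0.05 log units; within the scatter), which means that all three side chains now lie within the scatter of one another and none can be ranked. No measurement at hand explains why such different side chains read alike.

The compounds shown leave open whether a carboxylic acid at the end of the chain would also stay in this range. The same question stands for a plain alkyl chain with no nitrogen, which would show whether any amine or triazole is needed here.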